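This account rests on a few compounds, and the source may have more. Where it says the series, first, only, none or still open, it means among the compounds named here.

Measured compounds in a functional assay on HT-29 cells (Homo sapiens) for inhibition, read by MTT assay, with a stated time of 72 h; on this read-out higher numbers stand for weaker inhibition and lower numbers for stronger inhibition:
compound 1 `COc1ccc(CCCNCc2c(OC)cc(Oc3ccc(Nc4ccccc4)cc3)cc2OC)cc1` gives 6890 nM
compound 2 `CNCc1c(OC)cc(Oc2cccc(Nc3ccccc3)c2)cc1OC` gives 7430 nM
compound 3 `COc1cc(Oc2cccc(Nc3ccccc3)c2)cc(OC)c1CNCCNC(C)=O` gives 3960 nM

Compound 3 shows the lowest of the three numbers, but its gaps to compound 1 and to compound 2 are both within the scatter, so no order among the three can be read from these values. Among the compounds with values here, the single step between measured compounds that differ in one place, a 1.9-fold lower number from compound 2 to compound 3 (0.27 log units; within the scatter), also stays within the scatter.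

Compound 4 `CCN1CCN(Cc2c(OC)cc(Oc3cccc(Nc4ccccc4)c3)cc2OC)CC1` is not yet measured. It differs from compound 3 in one place: 4-ethylpiperazin-1-yl in place of (2-acetamidoethyl)amino on a saturated chain carbon bound to an aromatic carbon. Within the data shown here, the only measured step that bears on this region of the molecule is a 1.9-fold lower number from compound 2 to compound 3 (0.27 log units; within the scatter), which changed what is carried on the amine of the same side chain and moved the number by less than the scatter allows to call a change. Among the measured compounds shown here, no measured pair speaks to exchanging an open-chain amine for a piperazine ring, so nothing in the data points in either direction.

The step from compound 3 to compound 4 is therefore expected to be a 1.1-fold higher number from compound 3 to compound 4 (0.06 log units; within the scatter), that is, none beyond the scatter. For the measured compounds named here, for compound 4 in this assay the estimated value is 4500 nM, with an expected range from 1500 nM to 14000 nM, kept wide since no measured step supports this change directly.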

Compound 4, half-maximal inhibitory concentration: > 20000 nM
Compound 4: only a limit was reported (the forecaster's own chance of this, stated with the estimate: 5%); middle value at least 4.4-fold (0.64 log units) from the limit.
By their numbers in this assay, from the lowest: compounds 3, 1 and 2 (each within the scatter of the next). At a limit, above all of these: compound 4.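

In this assay compound 4 gives > 20000 nM, which is a limit of the assay and not a number. Even with that limit, the change on the saturated chain carbon bound to an aromatic carbon can be read: 4-ethylpiperazin-1-yl in place of (2-acetamidoethyl)amino gives an at least 5.0-fold higher number from compound 3 to compound 4 (0.70 log units; beyond the scatter), and 4-ethylpiperazin-1-yl in place of methylamino gives an at least 2.6-fold higher number from compound 2 to compound 4 (0.43 log units; beyond the scatter), while the earlier step, a 1.9-fold lower number from compound 2 to compound 3 (0.27 log units; within the scatter), stayed within the scatter. Within the data shown here, this position is therefore not indifferent to what it carries: the two open-chain amines of compound 2 and compound 3 give values within the scatter of each other, and the change to the 4-ethylpiperazin-1-yl ring is the first in this set to go beyond the scatter.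

From the compounds shown here alone, whether the limit goes with the ring itself or with the ethyl on it stays open, and an unsubstituted piperazine or a morpholine at this place would separate the two. Going by these compounds, how a dimethylamino group, an open-chain tertiary amine, would read at this place is also open.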